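Removing a Trifluoromethyl Group from a Fast-Cleared Compound

The source may report more compounds than this note shows. Statements on the series, on what has been measured and on what is new or still open speak of the compounds shown alone.

In an ADME assay on microsomes from liver (Homo sapiens) for metabolic stability (on this read-out higher numbers stand for fast clearance and lower numbers for slow clearance), compound 3 `CNC(=O)c1sc(N2CC3CC2(CNC(=O)c2c[nH]c4ncc(C(F)(F)F)cc24)C3)nc1C(F)(F)F` gives 130 mL.min-1.g-1 as the highest number among the measured compounds. Compound 1 `CNC(=O)c1cnc(Nc2ccc(OC)cc2C)nc1NC1CCCC1` comes nearest at 37 mL.min-1.g-1 and sits lower by a gap beyond the usual scatter. Compound 2 `COc1cc2c(Nc3cnc(NC(=O)c4cccn4C)nc3)ncnc2cc1OCCCNC1CCCC1` reports only a limit of the measurement, < 3 mL.min-1.g-1 in this case.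

Compound 4 `CNC(=O)c1sc(N2CC3CC2(CNC(=O)c2c[nH]c4ncccc24)C3)nc1C(F)(F)F` differs from compound 3 in one place, with hydrogen in place of trifluoromethyl on an aromatic carbon of a six-membered aromatic ring with 1 nitrogen hydrogen in place of trifluoromethyl on an aromatic carbon as the whole change. For the measured compounds named here, no two measured compounds differ in only one place, so no measured step shows what this change does, and the expectation is a judgement with wide margins. With compound 3 at 130 mL.min-1.g-1 near the fast end, a modest fall in clearance is expected, and the estimated change is a 2.2-fold lower number from compound 3 to compound 4 (0.34 log units; beyond the scatter) in this assay for this single swap. For compound 4 the expected value is 60 mL.min-1.g-1 with an estimated range from 22 mL.min-1.g-1 to 160 mL.min-1.g-1 around it.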

Compound 4, intrinsic clearance in microsomes: 200 mL.min-1.g-1
Estimate against measurement, compound 4: 3.3-fold (0.52 log units) below; measured number above the stated range.
By their numbers in this assay, from the lowest: compound 1; then compounds 3 and 4 (each within the scatter of the next). At a limit, below all of these: compound 2.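

In this assay, hydrogen in place of trifluoromethyl on this aromatic carbon, two atoms from the ring nitrogen, gives a 1.5-fold higher number from compound 3 to compound 4 (0.19 log units; within the scatter), so this swap produces no readable change in clearance. For the compounds shown here, this is the first comparison here between compounds that differ in only one place, and it shows that removing the trifluoromethyl at this position does not by itself turn this fast-cleared compound into a slowly cleared one. Nothing measured here explains why clearance stays so fast.

This single step cannot show whether another group at the same position, such as a nitrile or a carboxylic acid, would shift clearance. Also open, going by these compounds, is whether the clearance depends on another part of the molecule, such as the trifluoromethyl that compound 4 still shares with compound 3.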